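The source may report more compounds than this note shows. Statements on the series, on what has been measured and on what is new or still open speak of the compounds shown alone.

Within the data shown here, in a functional assay on SW-620 cells (Homo sapiens) for cytotoxicity, read by colorimetric assay (on this read-out higher numbers stand for weaker inhibition and lower numbers for stronger inhibition), compound 3 `O=C(NO)c1ccc(CN2C(=O)/C(=C3\Nc4ccccc4\C3=N/O)c3cc(F)ccc32)cc1` gives 20 nM, the lowest of the three numbers so far. Compound 1 `Cc1ccc2c(c1)/C(=C1/Nc3ccccc3/C1=N\O)C(=O)N2Cc1ccc(/C=C/C(=O)NO)cc1` gives 50 nM and compound 2 `O=C(NO)c1ccc(CN2C(=O)/C(=C3\Nc4ccccc4\C3=N/O)c3cc(Cl)ccc32)cc1` gives 60 nM. Compound 4 `Cc1ccc2c(c1)/C(=C1/Nc3ccccc3/C1=N\O)C(=O)N2Cc1ccc(C(=O)NO)cc1` differs from compound 3 by methyl in place of fluoro on an aromatic carbon, with methyl in place of fluoro on an aromatic carbon. Among the measured compounds shown here, no fluoro-to-methyl step has been measured. The nearest evidence is a 3.0-fold lower number from compound 2 to compound 3 (0.48 log units; beyond the scatter), a modest step with fluoro in place of chloro on an aromatic carbon. Losing the fluoro is therefore expected to bring a modest rise in this assay, not a further drop. The expected change is a 2.3-fold higher number from compound 3 to compound 4 (0.35 log units; beyond the scatter), similar in size to that step. For compound 4 the estimated value is 45 nM, with an expected range of 18 nM to 110 nM.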

Compound 4, half-maximal inhibitory concentration: 30 nM
Beside the measured number, compound 4's estimate is 1.5-fold (0.18 log units) above it; the measured number falls inside the stated range.
By their numbers in this assay, from the lowest: compounds 3, 4, 1 and 2 (each within the scatter of the next, the first and the last beyond it).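

In this assay, methyl on this aromatic carbon cannot be told apart from either halogen, with a 1.5-fold higher number from compound 3 to compound 4 (0.18 log units; within the scatter) and a 2.0-fold lower number from compound 2 to compound 4 (0.30 log units; within the scatter), so only the fluoro and chloro compounds stand resolved from each other. Hydroxycarbamoyl in place of 2-(hydroxycarbamoyl)ethenyl also leaves the number within the scatter, with a 1.7-fold lower number from compound 1 to compound 4 (0.22 log units; within the scatter). No measurement on hand offers an explanation for these results.

From the compounds shown here alone, whether a methoxy group or an amine on this aromatic carbon, or a longer chain carrying the hydroxycarbamoyl, would stay in this same range remains open.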